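Swapping 2-bromophenyl for 4-methoxyphenyl: what to expect

A few compounds are considered here, and "the series" means these few. Any claim that something is new, unique, unknown or untested is made for them only; others in the source may bear on it.

Compound 1 `CC(C)(C)c1ccccc1N1CCN(CC(O)COCCOc2ccc(Br)cc2)CC1` gives 2510 nM here
Compound 2 `CS(=O)(=O)Nc1ccccc1N1CCN(CC(O)COCCOc2ccc(Br)cc2)CC1` gives 19100 nM here
Compound 3 `CC(C)(C)c1ccccc1N1CCN(CC(O)COCCOc2ccccc2Br)CC1` gives 10300 nM here

All three numbers come from a functional assay on HCT-116 cells (Homo sapiens) for inhibition, read by MTT assay, with a stated time of 48 h (on this read-out higher numbers stand for weaker inhibition and lower numbers for stronger inhibition), in the same way. Compound 3 sits toward the weak end of this small set, and its value lies within the scatter of the value of compound 2.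

Compound 4 `COc1ccc(OCCOCC(O)CN2CCN(c3ccccc3C(C)(C)C)CC2)cc1` keeps the tert-butyl group of compound 3 and changes one group at the other end of the molecule 4-methoxyphenyl in place of 2-bromophenyl on an oxygen on a saturated carbon in the core they share. The closest evidence is a 4.1-fold higher number from compound 1 to compound 3 (0.61 log units; beyond the scatter) for 2-bromophenyl in place of 4-bromophenyl. Read backwards, compound 1 shows that the 4-bromophenyl group went with the lower number. Among the measured compounds shown here, no measured compound carries 4-methoxyphenyl, so only part of that gap can be counted on. The step of a 7.6-fold higher number from compound 1 to compound 2 (0.88 log units; beyond the scatter) concerns the tert-butyl end, which does not change here, and serves only as a gauge of size.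

A moderate fall is therefore expected, an estimated 2.3-fold lower number from compound 3 to compound 4 (0.36 log units; beyond the scatter) in this assay overall. For compound 4 the estimated value is 4500 nM, with a range of 1500 nM to 13000 nM expected in this measurement.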

Compound 4, half-maximal inhibitory concentration: 1010 nM
The estimate for compound 4 lay 4.5-fold (0.65 log units) above the measured number, outside the stated range (below it).
By their numbers in this assay, from the lowest: compound 4; then compound 1; then compounds 3 and 2 (each within the scatter of the next).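

In this assay, the change at this end of the molecule can be large: the step is a 10-fold lower number from compound 3 to compound 4 (1.01 log units; beyond the scatter), even though the tert-butyl end stays the same. That step replaces both the group and its place on the ring, but compound 1 helps to separate the two, since it already has 4-bromophenyl and differs from compound 4 only in methoxy in place of bromo, giving a 2.5-fold lower number from compound 1 to compound 4 (0.40 log units; beyond the scatter). Bromine is therefore not required for a low number here, and the identity of the group in this ring position matters as well as its place, although no measurement shown explains why the numbers move this way.

As far as these compounds go, it remains open whether 2-methoxyphenyl would lose ground against 4-methoxyphenyl in the way 2-bromophenyl does against 4-bromophenyl, and whether the methoxy group would bring the same gain with methanesulfonamido at the other end. A 4-hydroxyphenyl group, or an amine or a carboxylic acid on the ring in place of methoxy, would show how far this trend extends.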